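This account rests on a few compounds, and the source may have more. Where it says the series, first, only, none or still open, it means among the compounds named here.

The measured compounds in an assay on MCF7 cells for inhibition of Serine-protein kinase ATM (Homo sapiens), read by immunofluorescence, with a stated time of 1 h; a higher number here means a weaker inhibitor, a lower number a stronger inhibitor:

Compound 1, `COCCOc1cc2c(-n3nc(-c4ccccn4)nc3N)ncnc2cc1OC`, gives 1200 nM.
Compound 2, `CCN(CC)C(=O)COc1cc2c(-n3nc(-c4ccccn4)nc3N)ncnc2cc1OC`, gives 5300 nM.
Compound 3, `COc1cc2ncnc(-n3nc(-c4ccccn4)nc3N)c2cc1OCCCNC(=O)OC(C)(C)C`, gives 900 nM.

Compound 3 has the lowest of the three numbers. Its nearest neighbour is compound 1, and that step, a 1.3-fold lower number from compound 1 to compound 3 (0.12 log units; within the scatter), lies within the scatter, so no order between compound 1 and compound 3 can be claimed. The step of a 5.9-fold lower number from compound 2 to compound 3 (0.77 log units; beyond the scatter) is beyond the scatter and is the only clear gap among the three.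

Compound 4, `COc1cc2ncnc(-n3nc(-c4ccccn4)nc3N)c2cc1OCCCNC(=O)OCC(C)(C)C`, differs from compound 3 in one place: neopentyl in place of tert-butyl on an oxygen next to a carbonyl group. Going by the values given here, no measured step bears directly on this change. Among the compounds with values here, the steps of a 4.4-fold higher number from compound 1 to compound 2 (0.65 log units; beyond the scatter) and a 5.9-fold lower number from compound 2 to compound 3 (0.77 log units; beyond the scatter) replace the whole chain on the oxygen on the aromatic ring, while the one change that introduced the carbamate, a 1.3-fold lower number from compound 1 to compound 3 (0.12 log units; within the scatter), stayed within the scatter. Here the carbamate is kept and only the group on its oxygen is exchanged. A step no larger than the scatter is expected, no change at the digits printed from compound 3 to compound 4 (within the scatter), in no particular direction. Compound 4 is therefore estimated at 900 nM, with a range from 400 nM to 2000 nM.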

Compound 4, half-maximal inhibitory concentration: 1900 nM
Compound 4: the middle estimate sits 2.1-fold (0.32 log units) below what was measured; the measured number falls inside the stated range.
By their numbers in this assay, from the lowest: compounds 3, 1 and 4 (each within the scatter of the next, the first and the last beyond it); then compound 2.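

In this assay the group on the oxygen next to the carbonyl turns out to matter, since neopentyl in place of tert-butyl gives a 2.1-fold higher number from compound 3 to compound 4 (0.32 log units; beyond the scatter) and this modest step lies just beyond the scatter. With neopentyl, the carbamate chain still shows a clear gap to the diethylcarbamoyl chain, with a 2.8-fold lower number from compound 2 to compound 4 (0.45 log units; beyond the scatter) on that change, while a 1.6-fold higher number from compound 1 to compound 4 (0.20 log units; within the scatter) stays within the scatter and so separates compound 4 from the methoxy chain of compound 1 by nothing that can be claimed. No evidence is available to explain why this exchange shifts the number.

From the compounds shown here alone, with only tert-butyl and neopentyl at this oxygen, it remains open how a methyl, an ethyl or a benzyl group there would read. Also open, going by these compounds, is how the chain would read with a free amine or a simple amide at its end in place of the carbamate.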